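Shortening the sulfur-linked side chain in a dicyanopyridine series

The source may hold more compounds than are shown below. What is called first, only, known or untested is meant among the compounds shown, and "the series" means these compounds.

Three compounds share a core carrying two nitriles and an amino group, and all were examined in an assay on CHO cells for displacement of a labelled ligand from adenosine receptor A3 (Homo sapiens), read by scintillation counting, with a stated time of 120 min, tested at 1 uM; a lower number here means less inhibition, a higher number more inhibition at the concentration tested (going by the name of the read-out). Compound 1 `CCOc1ccc(-c2c(C#N)c(N)nc(SCc3ccn[nH]3)c2C#N)cc1` gives 18%, and compound 2 `N#Cc1c(N)nc2sc(C(N)=O)c(N)c2c1-c1ccc(OCC2CC2)cc1` gives 13%. Compound 3 `N#Cc1c(N)nc(SCc2cccc(C(N)=O)c2)c(C#N)c1-c1ccc(OCC2CC2)cc1` gives 1%, the lowest of the three numbers; the gap to compound 2 and the larger gap to compound 1 both lie beyond the scatter.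

Compound 4 `CNC(=O)CSc1nc(N)c(C#N)c(-c2ccc(OCC3CC3)cc2)c1C#N` has not yet been measured. It differs from compound 3 in one place: methylcarbamoyl in place of 3-carbamoylphenyl on a saturated chain carbon bound to a sulfur. The change removes the ring that made up most of the side chain and leaves a much shorter chain on the sulfur, while the amide is kept.

Going by the values given here, no step between measured compounds bears on this change, so the expectation rests on the spread of the three values. Compound 4 is expected to show a small rise, the step of a number 7 percentage points higher from compound 3 to compound 4 (within the scatter) estimated to stay within the scatter. For compound 4 the estimate in this assay is 8%, with a range from -5% to 25%.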

Compound 4, a percentage reported as inhibition, at one concentration (the size of the read-out at that concentration, not a potency): 3%
Beside the measured number, compound 4's estimate is 5 percentage points above it, within the range that was stated.
By their numbers in this assay, from the lowest: compounds 3, 4, 2 and 1 (each within the scatter of the next, the first and the last beyond it).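

In this assay, methylcarbamoyl in place of 3-carbamoylphenyl on a saturated chain carbon bound to a sulfur gives a number 2 percentage points higher from compound 3 to compound 4 (within the scatter), so at this position the read-out does not separate the side chain with the ring from the much shorter one without it. Both side chains keep the amide, and the loss of the ring and the drop from 9 heavy atoms to 4 leave no mark that can be read at the single concentration tested. Nothing available explains this result.

On these data alone, since both compounds carry an amide, its own part remains open, and a plain benzyl group or a carboxylic acid on the same chain would bear on it. As far as these compounds go, whether an amine or a longer chain at this position would give a number beyond the scatter also stays open.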